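A few compounds are considered here, and "the series" means these few. Any claim that something is new, unique, unknown or untested is made for them only; others in the source may bear on it.

Working notes on the series, all read in an ADME assay on MT4 cells (Homo sapiens) for cytotoxicity, read by MTT assay, with a stated time of 4 days; on this read-out higher numbers stand for lower toxicity in this test and lower numbers for higher toxicity in this test. Compound 1 (`O=c1cc(Cc2c(F)cccc2F)nc(N2CCCC2)[nH]1`) carries pyrrolidin-1-yl on the shared core, compound 2 (`CC1CCN(c2nc(Cc3c(F)cccc3F)cc(=O)[nH]2)CC1`) carries 4-methylpiperidin-1-yl and compound 3 (`O=c1cc(Cc2c(F)cccc2F)nc(N2CCCCCC2)[nH]1`) carries azepan-1-yl. Compound 1 gives only a limit, > 86000 nM. Compound 2 also gives only a limit, > 78000 nM. Compound 3 likewise stands at a limit, > 78000 nM, so it cannot be ranked against the other two.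

Compound 4 (`O=c1cc(Cc2c(F)cccc2F)nc(-n2cccc2)[nH]1`) has 1H-pyrrol-1-yl in place of azepan-1-yl on an aromatic carbon, between two ring nitrogen atoms: 1H-pyrrol-1-yl in place of azepan-1-yl on an aromatic carbon. Among the measured compounds shown here, the group that enters is aromatic, unlike the three measured so far, so the measured exchanges at this place are imperfect guides. For the measured compounds named here, with a step that the two limits leave unreadable from compound 1 to compound 3 and a step that the two limits leave unreadable from compound 2 to compound 3 as the only evidence, no step beyond the scatter is expected, and no direction can be assigned. The expected change is a step that the limit leaves unreadable from compound 3 to compound 4. The estimate for compound 4 is 85000 nM, with an expected range from 35000 nM to 95000 nM.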

Compound 4, half-maximal cytotoxic concentration: > 87000 nM
Compound 4 gave a limit, no number (the forecaster's own chance of this, stated with the estimate: 80%); middle value at least 1.0-fold (0.01 log units) from the limit.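

Compound 4, like compound 1, compound 2 and compound 3, gives only a limit in this assay, so no step among these compounds can be read. The compounds shown leave open whether exchanging these groups on the shared core changes the read-out at all: none gives a number.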